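Replacing the chloro group of compound 2

The source may report more compounds than this note shows. Statements on the series, on what has been measured and on what is new or still open speak of the compounds shown alone.

- Compound 1 `CCN1CCN(c2ccc3nnnc(Nc4cccc(OC(F)(F)F)c4)c3n2)CC1`: 14300 nM
- Compound 2 `FC(F)(F)Oc1cccc(Nc2nnnc3ccc(Cl)nc23)c1`: 8620 nM

Only these two compounds have been measured in a functional assay on LNCaP cells (Homo sapiens) for antiproliferative activity, read by MTT assay, with a stated time of 96 h (a lower number here means a stronger inhibitor, a higher number a weaker inhibitor), and their values lie within the scatter of each other. Compound 2, at 8620 nM, therefore stands level with compound 1, and neither can be called the better inhibitor.

The next compound is compound 3 `FC(F)(F)Oc1cccc(Nc2nnnc3ccc(NCC4CCNCC4)nc23)c1`, which differs from compound 2 as follows: ((piperidin-4-yl)methyl)amino in place of chloro on an aromatic carbon. In words, it carries ((piperidin-4-yl)methyl)amino in place of chloro on an aromatic carbon.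

Going by the values given here, one measured step bears on this change, since it also links chloro with a ring-bearing group: a 1.7-fold lower number from compound 1 to compound 2 (0.22 log units; within the scatter). Because a 1.7-fold lower number from compound 1 to compound 2 (0.22 log units; within the scatter) stayed within the scatter, no step beyond the scatter is expected in this assay, and no direction can be favoured. A single step is thin evidence, however, and 4-ethylpiperazin-1-yl is not the group that enters here, so the range must stay wide.

The estimated step is a 1.1-fold lower number from compound 2 to compound 3 (0.03 log units; within the scatter). For compound 3 the expected value is 8000 nM, with an estimated range of 2500 nM to 22000 nM.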

Compound 3, half-maximal inhibitory concentration: 11500 nM
Compound 3: the middle estimate sits 1.4-fold (0.16 log units) below what was measured, within the range that was stated.
By their numbers in this assay, from the lowest: compounds 2, 3 and 1 (each within the scatter of the next).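

In this assay, the position next to the ring nitrogen now has a second ring-bearing group to compare with chloro, and exchanging chloro for ((piperidin-4-yl)methyl)amino gives a 1.3-fold higher number from compound 2 to compound 3 (0.13 log units; within the scatter) and so no readable change. The two ring-bearing groups also stand level with each other, with a 1.2-fold lower number from compound 1 to compound 3 (0.09 log units; within the scatter) even though they are different groups, and the entering group brings hydrogen-bond donors that chloro does not have. Across all three compounds, then, no exchange at this place has moved the number beyond the scatter, and no measurement on hand offers an explanation for this flat picture.

From the compounds shown here alone, what remains open is whether any group at this place can shift the number clearly in either direction, for example a small primary amine, a methoxy group, or a carboxylic acid carried on a longer chain. Going by these compounds, it is also open whether the basic level of activity seen here is set by the rest of the molecule, such as the 3-(trifluoromethoxy)phenyl amine that all three compounds share, rather than by this position.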